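Methoxy to Hydroxy on a Pyrazole Urea Series

The compounds below may be only part of what the source reports. "The series", "measured", "known", "first", "only" and "open" are said of these compounds alone.

The measured compounds and their numbers in a functional assay on UACC-62 cells (Homo sapiens) for inhibition, read by sulforhodamine B assay, with a stated time of 48 h (on this read-out higher numbers stand for weaker inhibition of growth and lower numbers for stronger inhibition of growth), are: compound 1 `O=C(Nc1cccc(-n2cc(-c3ccncc3)c(-c3ccc(Cl)c(O)c3)n2)c1)Nc1cccc(C(F)(F)F)c1` with 1650 nM; compound 2 `O=C(Nc1cccc(-n2cc(-c3ccncc3)c(-c3ccc(Cl)c(O)c3)n2)c1)Nc1ccc(Cl)c(Cl)c1` with 1110 nM; compound 3 `COc1cc(-c2nn(-c3cccc(NC(=O)Nc4ccc(Cl)c(C(F)(F)F)c4)c3)cc2-c2ccncc2)ccc1Cl` with 737 nM.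

Among these three, compound 3 gives the lowest number; compound 2 lies within the scatter of it, while compound 1 lies beyond the scatter. Among the compounds with values here, the one step between single-change neighbours, a 1.5-fold lower number from compound 1 to compound 2 (0.17 log units; within the scatter), concerns the aryl group on the urea and does not touch the oxygen substituent.

Compound 4 `O=C(Nc1cccc(-n2cc(-c3ccncc3)c(-c3ccc(Cl)c(O)c3)n2)c1)Nc1ccc(Cl)c(C(F)(F)F)c1` differs from compound 3 only in this respect: hydrogen in place of methyl on an oxygen on an aromatic ring. Within the data shown here, no measured pair shows this change on its own, so the data give no direct guide to its size. Compounds 1 and 2 both carry the hydroxy group and give numbers close to that of compound 3, which suggests that the change is unlikely to move the number far in this assay. Compound 4 is therefore expected to show a 1.3-fold higher number from compound 3 to compound 4 (0.11 log units; within the scatter), a step not beyond the scatter, and its estimated value is 950 nM, with a range from 400 nM to 2200 nM.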

Compound 4, concentration for 50% growth inhibition: 627 nM
The estimate for compound 4 lay 1.5-fold (0.18 log units) above the measured number; measured number inside the range.
By their numbers in this assay, from the lowest: compounds 4, 3, 2 and 1 (each within the scatter of the next, the first and the last beyond it).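

Within the data shown here, the pair of compound 3 and compound 4 gives the first direct reading of methoxy to hydroxy on this oxygen: in this assay the step is small (a 1.2-fold lower number from compound 3 to compound 4 (0.07 log units; within the scatter)), so the two groups cannot be told apart on this read-out. Among these compounds, with the hydroxy group held fixed, trifluoromethyl in place of chloro also stays within the scatter (a 1.8-fold lower number from compound 2 to compound 4 (0.25 log units; within the scatter)), whereas chloro in place of hydrogen gives the first single-change step beyond it (a 2.6-fold lower number from compound 1 to compound 4 (0.42 log units; beyond the scatter)). Nothing available gives a reason for these numbers.

The compounds shown hold the methoxy and hydroxy pair on a single urea aryl group, so it stays open whether the same small step appears with other aryl groups. From the compounds shown here alone, it also stays open how an amine in place of the hydroxy, or a longer chain such as ethoxy on this oxygen, would read.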